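This account rests on a few compounds, and the source may have more. Where it says the series, first, only, none or still open, it means among the compounds named here.

Measured compounds:
- compound 1 `COc1cc(OC)c(OC)cc1/C=C/COC(=O)/C=C/c1c(OC)ccc(OC)c1OC` — 100%
- compound 2 `COc1cc(OC)c(OC)cc1/C=C/COC(=O)/C=C/c1ccc(Br)cc1` — 100%
- compound 3 `COc1cc(OC)c(OC)cc1/C=C/COC(=O)/C=C/c1ccc(OC)c(OC)c1OC` — 100%

In a functional assay on the whole organism (strain Kunming) with Mus musculus as the target, with a stated time of 0.5 h, at a dose of 300 mg/kg by the intraperitoneal route (on this read-out higher numbers stand for a weaker effect at the one dose given and lower numbers for a stronger effect), compound 2 gives 100%, level with compound 1 and compound 3 at the digits recorded; none of the three is separated from another beyond the scatter, so no ranking among them can be drawn. The series is varied only in the aryl group on the cinnamate side.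

Compound 4 `COc1cccc(/C=C/C(=O)OC/C=C/c2cc(OC)c(OC)cc2OC)c1` is not yet measured. Against compound 2 the change is 3-methoxyphenyl in place of 4-bromophenyl on a double-bonded chain carbon bound to a double-bonded chain carbon. For the measured compounds named here, no step between measured compounds is available to calibrate this change, and the three recorded values sit at a single level. The step from compound 2 to compound 4 is therefore expected to stay within the scatter, in either direction: no change at the digits printed from compound 2 to compound 4 (within the scatter) is the estimated step. For compound 4 the expected value in this assay is 100%, ranging from 85% to 100%.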

Compound 4, a percentage reported as activity, at one dose (the size of the read-out at that dose, not a potency): 100%
Compound 4: middle estimate and measured number agree at the digits printed; the range from low to high includes it.
By their numbers in this assay, from the lowest: compounds 1, 2, 3 and 4 (each within the scatter of the next).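

In this assay, for the compounds shown here, the exchange of 4-bromophenyl for 3-methoxyphenyl gives no change at the digits printed from compound 2 to compound 4 (within the scatter) and is the first single-place step that can be read. At this position, then, a bromine-bearing aryl group and a methoxy-bearing one cannot be told apart at the one dose given. No available data explain this result. Whether any group at this place can move the read-out stays open, since an aryl group bearing a carboxylic acid or a dimethylamino group is not among the compounds shown. The role of the shared core also remains unresolved.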